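Amide substituent variation on a trisulfated methyl glycoside series

This account rests on a few compounds, and the source may have more. Where it says the series, first, only, none or still open, it means among the compounds named here.

Measured so far:
compound 1 `CCN(CC(=O)NC[C@H]1O[C@H](OC)[C@@H](OS(=O)(=O)O)[C@@H](OS(=O)(=O)O)[C@@H]1OS(=O)(=O)O)C(=O)COS(=O)(=O)O`: 174000 nM
compound 2 `CO[C@H]1O[C@H](CNC(=O)CN(Cc2ccccc2)C(C)=O)[C@@H](OS(=O)(=O)O)[C@H](OS(=O)(=O)O)[C@@H]1OS(=O)(=O)O`: 140000 nM
compound 3 `CO[C@H]1O[C@H](CNC(=O)CN(CCOS(=O)(=O)O)C(C)=O)[C@@H](OS(=O)(=O)O)[C@H](OS(=O)(=O)O)[C@@H]1OS(=O)(=O)O`: 95000 nM

All three were read in an assay on isolated protein for binding affinity to fibroblast growth factor 1 (Homo sapiens), read by surface plasmon resonance; a higher number here means weaker binding, a lower number tighter binding. Compound 3 holds the lowest of the three numbers, yet both gaps to it stay within the scatter: a 1.8-fold lower number from compound 1 to compound 3 (0.26 log units; within the scatter); a 1.5-fold lower number from compound 2 to compound 3 (0.17 log units; within the scatter). The step between the other two is equally flat: a 1.2-fold lower number from compound 1 to compound 2 (0.09 log units; within the scatter). Across the three, the substituents on the amide-type nitrogen of the side chain vary widely, and the numbers do not.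

Compound 4 `CO[C@H]1O[C@H](CNC(=O)CN(C(C)=O)C2CCCCCC2)[C@@H](OS(=O)(=O)O)[C@H](OS(=O)(=O)O)[C@@H]1OS(=O)(=O)O` is the next member. Its change from compound 3: cycloheptyl in place of 2-(sulfooxy)ethyl on an amide-type nitrogen. The step that bears on it most directly sits on the same nitrogen, a 1.5-fold lower number from compound 2 to compound 3 (0.17 log units; within the scatter), where a phenyl gave way to a sulfooxymethyl without a shift; a 1.2-fold lower number from compound 1 to compound 2 (0.09 log units; within the scatter) also reworked this nitrogen with no movement. On this basis no step beyond the scatter is expected in this assay , in either direction.

Compound 4 is therefore estimated at 110000 nM, within 50000 nM to 250000 nM. The expected step is a 1.2-fold higher number from compound 3 to compound 4 (0.06 log units; within the scatter), nothing beyond the scatter.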

Compound 4, dissociation constant: 370000 nM
Compound 4: middle estimate off by 3.4-fold (0.53 log units), on the low side, outside the stated range (above it).
By their numbers in this assay, from the lowest: compounds 3, 2 and 1 (each within the scatter of the next); then compound 4.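

On the amide-type nitrogen, this position is no longer flat in this assay: cycloheptyl in place of 2-(sulfooxy)ethyl gives a 3.9-fold higher number from compound 3 to compound 4 (0.59 log units; beyond the scatter), cycloheptyl in place of benzyl gives a 2.6-fold higher number from compound 2 to compound 4 (0.42 log units; beyond the scatter), and acetyl(cycloheptyl)amino in place of ethyl(((sulfooxy)methyl)carbonyl)amino gives a 2.1-fold higher number from compound 1 to compound 4 (0.33 log units; beyond the scatter). All three steps run toward weaker binding, so compound 4 stands apart from compounds 1, 2 and 3, which remain within the scatter of each other, and the earlier exchanges on this nitrogen did not show the full range of the position. No supporting data bear on what sets cycloheptyl apart here.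

Open, from the compounds shown here alone, is whether the shift follows the ring or the seven carbons of cycloheptyl; a cyclopentyl ring and an open heptyl chain on the same nitrogen would separate the two. Also open, going by these compounds, is whether a carboxylic acid or an amine on the cycloheptyl ring would return the number to the level of compound 3.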